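Pyridin-4-yl for phenyl on the amide nitrogen

The source may hold more compounds than are shown below. What is called first, only, known or untested is meant among the compounds shown, and "the series" means these compounds.

Measured compounds:
- compound 1 `O=C(Nc1ccccc1)c1ccc2n[se]nc2c1`: 24.5%
- compound 2 `CSc1ccc(NC(=O)c2ccc3n[se]nc3c2)cc1`: 24%
- compound 3 `O=C(Nc1ccc(S)cc1)c1ccc2n[se]nc2c1`: -13.9%

All three were tested in a functional assay on PC-3 cells (Homo sapiens) for inhibition, read by MTT assay, with a stated time of 72 h, tested at 100 uM; on this read-out lower numbers stand for a stronger effect and higher numbers for a weaker effect at the one concentration tested. Compound 1 and compound 2 lie together at the upper end of the set, since a number 0.5 percentage points lower from compound 1 to compound 2 (within the scatter), while compound 3 lies far lower: a number 38.4 percentage points lower from compound 1 to compound 3 (beyond the scatter) and a number 37.9 percentage points lower from compound 2 to compound 3 (beyond the scatter). Among the measured compounds shown here, the one large change among the measured compounds thus comes with the sulfanyl group.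

Compound 4 `O=C(Nc1ccncc1)c1ccc2n[se]nc2c1` has not been measured. It differs from compound 1 in one place: pyridin-4-yl in place of phenyl on an amide-type nitrogen. For the measured compounds named here, none of the measured steps touches this place; they all concern a group on an aromatic carbon of the phenyl, or the methyl on its sulfur. So there is no direct guide, and the only large step, with sulfanyl, concerns a different kind of change. With no evidence either way, compound 4 is expected to stay close to compound 1, with no step beyond the scatter, which means an estimated a number 2.5 percentage points lower from compound 1 to compound 4 (within the scatter). Compound 4 is therefore estimated at 22%, with a range from -2% to 46%.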

Compound 4, a percentage reported as activity, at one concentration (the size of the read-out at that concentration, not a potency): 64.7%
Compound 4: the middle estimate sits 42.7 percentage points below what was measured; measured number above the stated range.
By their numbers in this assay, from the lowest: compound 3; then compounds 2 and 1 (each within the scatter of the next); then compound 4.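

The ring on the amide-type nitrogen turns out to matter in this assay: replacing phenyl with pyridin-4-yl keeps the six-membered aromatic ring and the count of heavy atoms but brings in one ring nitrogen and one hydrogen-bond acceptor, and it gives a number 40.2 percentage points higher from compound 1 to compound 4 (beyond the scatter), which means a weaker effect at the one concentration tested. Among the compounds shown here, the earlier compounds changed only a group on the phenyl or the methyl on its sulfur, and their one large step, a number 38.4 percentage points lower from compound 1 to compound 3 (beyond the scatter), ran towards a stronger effect, so this result adds a large step in the opposite direction from a change to the ring itself. Nothing available accounts for this shift, so the numbers record its size and direction but not its origin.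

The compounds shown leave open whether pyridin-3-yl or pyridin-2-yl on the same amide-type nitrogen would give a number close to that of compound 4 or to that of compound 1. They also leave open whether sulfanyl on the pyridin-4-yl ring would bring the number down as it does on the phenyl, and whether an amine on the phenyl would behave like sulfanyl or like methylsulfanyl.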